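This account rests on a few compounds, and the source may have more. Where it says the series, first, only, none or still open, it means among the compounds named here.

Working notes on the series, all read in a functional assay on the whole organism (Tail, strain ICR) with Mus musculus as the target, in the tail flick test, with a stated time of 90 min, at a dose of 25 umol/kg by the oral route; on this read-out higher numbers stand for a stronger effect at the one dose given and lower numbers for a weaker effect.

Three compounds share one core and differ in the side chain on the saturated chain carbon. Compound 1 `CSCC[C@H](NC(=O)CN(c1nc(Cl)nc2[nH]cnc12)C1CC1)C(=O)OCc1ccccc1` gives 44.6% in this assay. Compound 2 `N=C(N)NCCC[C@H](NC(=O)CN(c1nc(Cl)nc2[nH]cnc12)C1CC1)C(=O)OCc1ccccc1` gives 30.4%, and compound 3 `O=C(CN(c1nc(Cl)nc2[nH]cnc12)C1CC1)N[C@@H](CC(=O)OCc1ccccc1)C(=O)OCc1ccccc1` gives 15.6%. Compound 3 stands lowest of the three, and both gaps to it lie beyond the scatter: a number 14.8 percentage points lower from compound 2 to compound 3 (beyond the scatter), and a number 29 percentage points lower from compound 1 to compound 3 (beyond the scatter).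

Compound 4 `NCCCC[C@H](NC(=O)CN(c1nc(Cl)nc2[nH]cnc12)C1CC1)C(=O)OCc1ccccc1` is not yet measured. It differs from compound 3 as follows: 3-aminopropyl in place of benzyloxycarbonyl on a saturated chain carbon, two bonds along the chain from an amide-type nitrogen and a carbonyl carbon.

Within the data shown here, two measured steps bear on this change. The step of a number 29 percentage points lower from compound 1 to compound 3 (beyond the scatter) shows that putting benzyloxycarbonyl on that carbon lowered the number by a modest amount; compound 4 removes that same group, so the reverse direction is expected. The step of a number 14.8 percentage points lower from compound 2 to compound 3 (beyond the scatter) shows the move from a nitrogen-bearing chain to the aromatic ester also cost a modest amount, and compound 4 brings back a nitrogen-bearing chain, shorter than that of compound 2. Taken together, a modest rise is expected, landing near compound 2 and below compound 1.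

The expected step is a number 17.4 percentage points higher from compound 3 to compound 4 (beyond the scatter), so compound 4 is estimated at 33%, within 18% to 50%.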

Compound 4, a percentage reported as activity, at one dose (the size of the read-out at that dose, not a potency): 35.3%
Compound 4: middle estimate off by 2.3 percentage points, on the low side; the measured number falls inside the stated range.
By their numbers in this assay, from the lowest: compound 3; then compounds 2, 4 and 1 (each within the scatter of the next, the first and the last beyond it).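

In this assay, 3-aminopropyl in place of benzyloxycarbonyl on a saturated chain carbon, two bonds along the chain from an amide-type nitrogen and a carbonyl carbon, gives a number 19.7 percentage points higher from compound 3 to compound 4 (beyond the scatter), so a third chain without an aromatic ring now stands clear of compound 3, and among the four compounds none goes against this. The chain of compound 4 adds no separation from the other two chains: a number 4.9 percentage points higher from compound 2 to compound 4 (within the scatter) and a number 9.3 percentage points lower from compound 1 to compound 4 (within the scatter) both lie within the scatter, even though the step between compound 1 and compound 2 lies beyond it, so compound 4 cannot be ranked against either of them. No measurement at hand gives a reason for these steps.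

The compounds shown leave open whether the low number of compound 3 goes with its aromatic ring or with its ester, a question that a carboxylic acid or a plain benzyl group on that carbon would help to separate. On these data alone, it also remains open how the number responds to chain length, which a longer chain ending in an amine would test against compound 4.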